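Swapping the Amide Arm for a Basic Amine Chain

A few compounds are considered here, and "the series" means these few. Any claim that something is new, unique, unknown or untested is made for them only; others in the source may bear on it.

Measured so far:
Compound 1, `COc1cc2c(cc1NS(=O)(=O)c1cccc(Cl)c1Cl)[nH]c(=O)n2CC(N)=O`, gives 457 nM in a functional assay on CHO cells for antagonist activity at C-C chemokine receptor type 4 (Homo sapiens), read by radioligand binding and GTPgammaS binding; a higher number here means a weaker inhibitor, a lower number a stronger inhibitor.
Compound 2, `COc1cc2c(cc1NS(=O)(=O)c1cccc(Cl)c1Cl)[nH]c(=O)n2C1COC1`, gives 112 nM in this assay.

Of these two numbers compound 1 stands highest, so it is the weaker inhibitor of the pair. Going by the values given here, the one measured step runs a 4.1-fold lower number from compound 1 to compound 2 (0.61 log units; beyond the scatter), with oxetan-3-yl in place of carbamoylmethyl on the aromatic nitrogen of the shared core.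

Compound 3, `COc1cc2c(cc1NS(=O)(=O)c1cccc(Cl)c1Cl)[nH]c(=O)n2CCN(C)C`, is not yet measured. It differs from compound 1 by (dimethylamino)methyl in place of carbamoyl on a saturated chain carbon bound to an aromatic nitrogen. Among the compounds with values here, no measured step exchanges the carbamoyl for an amine, so the step from compound 1 to compound 2 bears on it only loosely: it shows that what sits on that nitrogen can shift the number beyond the scatter. A modest drop, within the scatter or a little past it, is expected: a 1.8-fold lower number from compound 1 to compound 3 (0.26 log units; within the scatter). Compound 3 is estimated at 250 nM, with a range from 60 nM to 1000 nM in this assay.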

Compound 3, half-maximal inhibitory concentration: 2000 nM
Compound 3: middle estimate off by 8.0-fold (0.90 log units), on the low side, and the stated range ends below it.
By their numbers in this assay, from the lowest: compound 2; then compound 1; then compound 3.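

Going by these compounds alone, the earlier pair showed only that a change on this aromatic nitrogen can strengthen inhibition, whereas compound 3 shows that a change there can also weaken it. In this assay, replacing carbamoyl with (dimethylamino)methyl on the saturated chain carbon gives a clear loss (a 4.4-fold higher number from compound 1 to compound 3 (0.64 log units; beyond the scatter)), and measured against the oxetan-3-yl group, the 2-(dimethylamino)ethyl group gives a larger one (an 18-fold higher number from compound 2 to compound 3 (1.25 log units; beyond the scatter)). Nothing available here accounts for either loss.

Going by these compounds, it remains open whether these losses belong to the dimethylamino group itself or to the ethyl chain that carries it. A longer chain ending in the same amine, a pyrrolidine in place of the dimethylamino group, or a carboxylic acid on the chain would help separate these two readings.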